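Swapping the aryl group on a thiazole-linked acid

The source may hold more compounds than are shown below. What is called first, only, known or untested is meant among the compounds shown, and "the series" means these compounds.

Measured compounds:
compound 1 `Cc1ccccc1-c1nc(C)c(COc2ccc3c(c2)OCC3CC(=O)O)s1`: gives "not determined" (no result reported) in a functional assay on CHO cells for agonist activity at Free fatty acid receptor 1 (Homo sapiens), read by FLIPR and calcium flux; a higher number here means that more compound is needed for the effect, a lower number that less compound is needed
compound 2 `Cc1nc(-c2ccccc2Cl)sc1COc1ccc2c(c1)OCC2CC(=O)O`: gives "not determined" (no result reported) in this assay
compound 3 `Cc1nc(-c2cccc(F)c2)sc1COc1ccc2c(c1)OCC2CC(=O)O`: gives 64.8 nM in this assay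

Compound 2 stands without a number: in this assay compound 2 gives "not determined" (no result reported). The same is true of compound 1, which in this assay gives "not determined" (no result reported), so nothing about the strength of compound 2 can be read from these data. Compound 4 `COc1ccc(-c2nc(C)c(COc3ccc4c(c3)OCC4CC(=O)O)s2)cc1` differs from compound 2 in one place: 4-methoxyphenyl in place of 2-chlorophenyl on an aromatic carbon. Among the compounds with values here, no measured pair shows this change, and with no value for compound 2 the step to compound 4 cannot be given a direction; the expectation is a step no larger than the scatter. For compound 4 an estimate of 80 nM is expected, ranging from 20 nM to 400 nM, resting on compound 3 with its 64.8 nM on the shared core.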

Compound 4, half-maximal effective concentration: 123 nM
Beside the measured number, compound 4's estimate is 1.5-fold (0.19 log units) below it, and the stated range covers the measured number.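

In this assay, this position on the thiazole now has two readable aryl groups: 4-methoxyphenyl in place of 3-fluorophenyl gives a 1.9-fold higher number from compound 3 to compound 4 (0.28 log units; within the scatter), so this change does not move the number beyond normal repeat variation. Steps from compound 1 or compound 2 cannot be read, so 2-chlorophenyl and the methylphenyl group of compound 1 remain unplaced. Nothing measured here explains the result. As far as these compounds go, it remains open how an aminophenyl group, a carboxyphenyl group or a pyridine ring would behave at this position.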